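Imine aryl swap on two cores: notes toward compound 4

A few compounds are considered here, and "the series" means these few. Any claim that something is new, unique, unknown or untested is made for them only; others in the source may bear on it.

Measured so far in a functional assay on HCT-116 cells (Homo sapiens) for antiproliferative activity, read by MTT assay; on this read-out lower numbers stand for stronger inhibition and higher numbers for weaker inhibition:
- compound 1 `NS(=O)(=O)c1ccc(Nc2ncc(/N=C/c3cccs3)c(NC3CCCC3)n2)cc1`: 13300 nM
- compound 2 `NS(=O)(=O)c1ccc(Nc2ncc(/N=C/c3ccc(C(F)(F)F)cc3)c(NC3CCCC3)n2)cc1`: returns only a limit, > 100000 nM
- compound 3 `CC(C)Nc1nc(Nc2ccc(N3CCN(C)CC3)cc2)ncc1/N=C/c1cccs1`: returns only a limit, > 100000 nM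

In this assay the change from compound 1 to compound 2 is 4-(trifluoromethyl)phenyl in place of thiophen-2-yl on a carbon with a double bond to nitrogen and produces an at least 7.5-fold higher number from compound 1 to compound 2 (0.87 log units; beyond the scatter). Two of the three values sit at the limit of > 100000 nM in this assay, at which 2 of the 3 values shown sit. Compound 4 `CC(C)Nc1nc(Nc2ccc(N3CCN(C)CC3)cc2)ncc1/N=C/c1ccc(C(F)(F)F)cc1` awaits measurement; it differs from compound 3 by the same change, (4-(trifluoromethyl)phenyl in place of thiophen-2-yl on a carbon with a double bond to nitrogen). The difference between the two cores is not broken down here. Compound 3 already stands at a limit, > 100000 nM. Because the earlier step of an at least 7.5-fold higher number from compound 1 to compound 2 (0.87 log units; beyond the scatter) weakened activity, compound 4 is expected to show no stronger inhibition, an expected step that the limit leaves unreadable from compound 3 to compound 4. The estimate for compound 4 is 200000 nM, expected between 100000 nM and 600000 nM.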

Compound 4, half-maximal inhibitory concentration: 42200 nM
For compound 4 the middle estimate is 4.7-fold (0.68 log units) above the measured one; measured number below the stated range.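

On the core of compound 3, 4-(trifluoromethyl)phenyl in place of thiophen-2-yl gives an at least 2.3-fold lower number from compound 3 to compound 4 (0.37 log units; beyond the scatter) in this assay. The change therefore does not carry over from one core to the other with the same direction or size: the same change on two cores in this assay, an at least 7.5-fold higher number (0.87 log units; beyond the scatter) from compound 1 to compound 2 and an at least 2.3-fold lower number (0.37 log units; beyond the scatter) from compound 3 to compound 4, at least 17-fold (1.25 log units) apart, beyond the scatter of two such steps

This rests on one pair per core, and each step has a limit at one end, so neither true size can be read, and nothing shows which part of the core goes with the difference. The compounds shown leave open whether the opposite steps follow the cyclopentyl against the isopropyl group, or the sulfonamide against the methylpiperazine. Also open, as far as these compounds go, is how a nitrile or a carboxylic acid in place of the trifluoromethyl would behave on each core.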